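The compounds below may be only part of what the source reports. "The series", "measured", "known", "first", "only" and "open" are said of these compounds alone.

Working notes on the series. Compound 2 `CC(C)(C)OC(=O)c1cccc(NC(=O)C2CCCN(C(=O)c3cc(C(F)(F)F)cc(C(F)(F)F)c3)C2)c1` in an ADME assay on PC-3 cells (Homo sapiens) for cytotoxicity, read by WST assay, tested at 100 uM (a lower number here means less inhibition, a higher number more inhibition at the concentration tested (going by the name of the read-out)), gives 0%, level with compound 3 `COC(=O)c1cccc(C(=O)N2CCCC(C(=O)Nc3ccc(Cl)cc3)C2)c1`, which gives 0%; together these are the lowest of the three numbers, while compound 1 `O=C(Nc1ccc(Cl)cc1)C1CCCN(C(=O)c2cccc(-c3nccs3)c2)C1` gives 32%. For the measured compounds named here, the only measured step, a number 32 percentage points lower from compound 1 to compound 3 (beyond the scatter), concerns a different exchange at a different position and so bears only loosely on the move to compound 4 `O=C(Nc1cccc(OCCc2ccccn2)c1)C1CCCN(C(=O)c2cc(C(F)(F)F)cc(C(F)(F)F)c2)C1`, where (2-(pyridin-2-yl)ethoxy in place of tert-butoxycarbonyl on an aromatic carbon). Going by the values given here, no measured pair covers an exchange of this kind, and nothing here indicates a rise beyond the scatter. For compound 4 the estimate in this assay is therefore 5%, with a range from 0% to 25%. The step expected is accordingly a number 5 percentage points higher from compound 2 to compound 4 (within the scatter), none beyond the scatter.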

Compound 4, a percentage reported as inhibition, at one concentration (the size of the read-out at that concentration, not a potency): 5%
Compound 4: the middle estimate sits on the measured number at the digits printed, and the stated range covers the measured number.
By their numbers in this assay, from the lowest: compounds 2, 3 and 4 (each within the scatter of the next); then compound 1.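

In this assay, 2-(pyridin-2-yl)ethoxy in place of tert-butoxycarbonyl on an aromatic carbon, meta to a large group, gives a number 5 percentage points higher from compound 2 to compound 4 (within the scatter). For the compounds shown here, this is the first reading at this position, and it shows that a group with a six-membered aromatic ring can replace an open-chain ester there with no change beyond the scatter. No measured data bear on why this exchange behaves this way.

From the compounds shown here alone, whether a carboxylic acid or an amine at this position would also stay within the scatter of compound 2 remains open. So does whether the same exchange would behave alike on the core of compound 1.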